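Chloro addition on the aryl ring of compound 2

A few compounds are considered here, and "the series" means these few. Any claim that something is new, unique, unknown or untested is made for them only; others in the source may bear on it.

Measured compounds:
compound 1, `COc1ccc(-n2c(C)nc3c(NC(C4CC4)C4CC4)nc(C)nc32)cc1`: 12 nM
compound 2, `Cc1nc(NC(C2CC2)C2CC2)c2nc(C)n(-c3ccc(OC(F)F)cc3)c2n1`: 3 nM

In an assay on CHO cells for binding affinity to corticotropin-releasing factor receptor 1 (Homo sapiens) (on this read-out higher numbers stand for weaker binding and lower numbers for tighter binding), compound 1 gives 12 nM and compound 2 gives 3 nM. Among the compounds with values here, the single measured step, a 4.0-fold lower number from compound 1 to compound 2 (0.60 log units; beyond the scatter), places compound 2 at the lowest of the two numbers, with compound 1 the nearest neighbour and beyond the scatter.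

Compound 3, `Cc1nc(NC(C2CC2)C2CC2)c2nc(C)n(-c3ccc(OC(F)F)cc3Cl)c2n1`, is not yet measured. Its change from compound 2 is chloro in place of hydrogen on an aromatic carbon of a six-membered aromatic ring of carbon only, ortho to a large group and meta to the difluoromethoxy group.

Within the data shown here, no measured step touches an aromatic carbon of that ring; the only step on record, a 4.0-fold lower number from compound 1 to compound 2 (0.60 log units; beyond the scatter), concerns the group on the oxygen and so gives no direct reading for the chloro substitution. Without a step that bears on it, the expectation for compound 3 in this assay is a change of about no change at the digits printed from compound 2 to compound 3 (within the scatter), that is none beyond the scatter. Compound 3 is therefore estimated at 3 nM, expected between 1.2 nM and 8 nM.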

Compound 3, dissociation constant: 0.373 nM
Estimate against measurement, compound 3: 8.0-fold (0.91 log units) above; measured number below the stated range.
By their numbers in this assay, from the lowest: compound 3; then compound 2; then compound 1.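

Chloro in place of hydrogen on an aromatic carbon, ortho to a large group and meta to a difluoromethoxy group, gives an 8.0-fold lower number from compound 2 to compound 3 (0.91 log units; beyond the scatter) in this assay and so shows that this ring carbon can move the read-out, which the earlier compounds could not show. Within the data shown here, the only earlier step, a 4.0-fold lower number from compound 1 to compound 2 (0.60 log units; beyond the scatter), changed the group on the oxygen and left this ring carbon bearing hydrogen; the new step runs in the same direction, towards tighter binding, from a different place on the same ring. No supporting data on this series bear on the reason for the new step.

A single chloro is the only group shown at this ring carbon, so it remains open whether fluoro, bromo, methyl or nitrile there would give a step of similar direction and size. From the compounds shown here alone, it also remains open whether the chloro step holds with the methoxy group of compound 1 on the oxygen, or whether it depends on the difluoromethoxy group of compound 2.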